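The compounds below may be only part of what the source reports. "The series", "measured", "known", "first", "only" and "open" are said of these compounds alone.

Compound 1 `O=c1c2ccccc2[se]n1-c1nnc(-c2ccc(Cl)cc2)s1` was tested in a functional assay on A549 cells (Homo sapiens) for antiproliferative activity, read by CCK-8 assay, with a stated time of 48 h (a lower number here means a stronger inhibitor, a higher number a weaker inhibitor), and compound 1 gave 10400 nM. Compound 2 `COc1ccc(-c2nnc(-n3[se]c4ccccc4c3=O)s2)cc1` in this assay gave 5930 nM, and the step of a 1.8-fold lower number from compound 1 to compound 2 (0.24 log units; within the scatter) does not separate the two, so compound 1 stands alongside compound 2 on the numbers shown. Compound 3 `O=c1c2ccccc2[se]n1-c1nnc(-c2ccccc2Cl)s1` differs from compound 1 by 2-chlorophenyl in place of 4-chlorophenyl on an aromatic carbon. Within the data shown here, the only step measured, a 1.8-fold lower number from compound 1 to compound 2 (0.24 log units; within the scatter), replaces the group itself and lies within the scatter, so no step beyond the scatter is expected in this assay. Compound 3 is therefore estimated at 10000 nM, between 4000 nM and 25000 nM. This estimate means an expected 1.0-fold lower number from compound 1 to compound 3 (0.02 log units; within the scatter).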

Compound 3, half-maximal inhibitory concentration: 10100 nM
Compound 3: the middle estimate sits 1.0-fold (0.00 log units) below what was measured; measured number inside the range.
By their numbers in this assay, from the lowest: compounds 2, 3 and 1 (each within the scatter of the next).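

In this assay, 2-chlorophenyl in place of 4-chlorophenyl gives a 1.0-fold lower number from compound 1 to compound 3 (0.01 log units; within the scatter). The earlier pair exchanged chloro for methoxy, whereas this pair keeps the same atoms joined differently, and the numbers still do not separate the two compounds. No measurement available here accounts for this result.

From the compounds shown here alone, whether an amine or a carboxylic acid in place of the chloro would give a step beyond the scatter stays open, as does the effect of any change to the shared core.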